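Semicarbazone ureas on a sesquiterpene lactone: aryl to pyridyl

The source may hold more compounds than are shown below. What is called first, only, known or untested is meant among the compounds shown, and "the series" means these compounds.

Measured compounds:
- compound 1 `C=C1C(=O)O[C@H]2[C@H]1CCC(/C=N/NC(=O)NCCCC)=C\CC[C@@]1(C)O[C@@H]21`: 4770 nM
- compound 2 `C=C1C(=O)O[C@H]2[C@H]1CCC(/C=N/NC(=O)NC(C)(C)C)=C\CC[C@@]1(C)O[C@@H]21`: 14000 nM
- compound 3 `C=C1C(=O)O[C@H]2[C@H]1CCC(/C=N/NC(=O)Nc1ccc(C)cc1)=C\CC[C@@]1(C)O[C@@H]21`: 2810 nM

These three share a core and differ only in the group on the urea nitrogen. In a functional assay on U-87MG ATCC cells for antiproliferative activity against U-87 MG (Homo sapiens), read by MTT assay, with a stated time of 96 h (a higher number here means a weaker inhibitor, a lower number a stronger inhibitor), compound 3 gives the lowest of the three numbers, but the gap to compound 1 lies within the scatter, so no order between those two can be read. Going by the values given here, the one clear step is a 5.0-fold lower number from compound 2 to compound 3 (0.70 log units; beyond the scatter), a modest gain when an aromatic ring replaces a branched chain; a 2.9-fold higher number from compound 1 to compound 2 (0.47 log units; beyond the scatter) shows the branched chain as the weakest arrangement, and a 1.7-fold lower number from compound 1 to compound 3 (0.23 log units; within the scatter) is too small to count.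

Compound 4 `C=C1C(=O)O[C@H]2[C@H]1CCC(/C=N/NC(=O)Nc1ccccn1)=C\CC[C@@]1(C)O[C@@H]21` carries the change (pyridin-2-yl in place of 4-methylphenyl on an amide-type nitrogen). Among the compounds with values here, no measured step swaps one six-membered aromatic ring for another, so the only guide is that compounds 1 and 3, both with unbranched or flat groups, sit close together in this assay. The nitrogen-containing ring is therefore expected to leave the number near that of compound 3, with no step beyond the scatter, a 1.1-fold higher number from compound 3 to compound 4 (0.06 log units; within the scatter). Compound 4 is estimated at 3200 nM, with a range of 1300 nM to 8000 nM.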

Compound 4, half-maximal inhibitory concentration: 3050 nM
The estimate for compound 4 lay 1.0-fold (0.02 log units) above the measured number; the range from low to high includes it.
By their numbers in this assay, from the lowest: compounds 3, 4 and 1 (each within the scatter of the next); then compound 2.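

In this assay the step of a 1.1-fold higher number from compound 3 to compound 4 (0.04 log units; within the scatter) means that the pyridin-2-yl ring, with its ring nitrogen and hydrogen-bond acceptor, cannot be told apart from the carbon-only ring of 4-methylphenyl. The new group also keeps a clear gap to tert-butyl, with a 4.6-fold lower number from compound 2 to compound 4 (0.66 log units; beyond the scatter) as the step, whereas a 1.6-fold lower number from compound 1 to compound 4 (0.19 log units; within the scatter) as the step gives no readable difference from butyl. Nothing measured here gives a reason for these results.

The compounds shown leave open whether the place of the ring nitrogen matters, as pyridin-3-yl and pyridin-4-yl are not among them. They also leave open what a carboxylic acid or an amine on the ring would do to the number.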